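Benzoxaborole-free and benzoxaborole-bearing enones: a bromophenyl variant

The source may hold more compounds than are shown below. What is called first, only, known or untested is meant among the compounds shown, and "the series" means these compounds.

Compound 1 `O=C(/C=C/c1ccc2c(c1)B(O)OC2)c1ccccn1` bears a pyridin-2-yl on a carbonyl carbon attached to the shared core. In an ADME assay on L929 cells (Mus musculus) for cytotoxicity, read by resazurin assay, with a stated time of 72 h (on this read-out higher numbers stand for weaker inhibition and lower numbers for stronger inhibition), compound 1 gives only a limit of the assay, > 10 ug/mL. Compound 3 `O=C(/C=C/c1ccc2c(c1)B(O)OC2)c1ccc(O)c(O)c1` has the same core and in this assay also reaches only a limit, > 10 ug/mL. Compound 2 `COc1cccc(C(=O)/C=C/c2ccccc2)c1`, which does not have that core, gives a number in this assay, 5.7 ug/mL. Compound 1 therefore stands at the edge of what this assay can report, as seen in the limit of > 10 ug/mL in this assay, at which 2 of the 3 values shown sit, so its distance from compound 2 is known only as a bound, not as a measured gap.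

Compound 4 `O=C(/C=C/c1ccc2c(c1)B(O)OC2)c1ccc(Br)cc1` remains to be measured. Against compound 1 the change is 4-bromophenyl in place of pyridin-2-yl on a carbonyl carbon. Going by the values given here, no two measured compounds differ in a single place, so no measured step sets the scale here. The expectation is a step in this assay no larger than the scatter, or at most a modest move toward stronger inhibition. Compound 4 is expected to sit close to the limit, the expected step being a number no higher from compound 1 to compound 4 (the limit leaves the size open). For compound 4 the estimate is 10 ug/mL, with a range from 4 ug/mL to 30 ug/mL.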

Compound 4, half-maximal inhibitory concentration: > 10 ug/mL
Compound 4: only a limit was reported; the forecaster's own chance of this, stated with the estimate: 55%; the middle value lies on the limit itself.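

No step can be read from compound 1 to compound 4, because both give only a limit in this assay: the limit of > 10 ug/mL in this assay, at which 3 of the 4 values shown sit. The compounds shown leave open whether 4-bromophenyl in place of pyridin-2-yl on a carbonyl carbon shifts the read-out at all, and by how much.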